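Extending the chain of compound 3 to octyl

A few compounds are considered here, and "the series" means these few. Any claim that something is new, unique, unknown or untested is made for them only; others in the source may bear on it.

Compound 3 `CCCN(Cc1ccc(C(=O)NO)cc1)c1ncc(-c2ccc(C)cc2)s1` stands second highest of the three numbers in a functional assay on HCT-116 cells (Homo sapiens) for antiproliferative activity, read by MTT assay, with a stated time of 48 h (on this read-out lower numbers stand for stronger inhibition of growth and higher numbers for weaker inhibition of growth), with compound 3 giving 5800 nM; compound 1 `Cc1ccc(OCCCCN(Cc2ccc(C(=O)NO)cc2)c2ncc(-c3ccc(C)cc3)s2)cc1` gives 580 nM and compound 2 `Cc1ccc(OCCCN(Cc2ccc(C(=O)NO)cc2)c2ncc(-c3ccc(C)cc3)s2)cc1` gives 12600 nM. Compound 4 `CCCCCCCCN(Cc1ccc(C(=O)NO)cc1)c1ncc(-c2ccc(C)cc2)s1` differs from compound 3 by pentyl in place of hydrogen on a saturated chain carbon, three bonds along the chain from a nitrogen on an aromatic ring. The step that bears on it is a 10-fold higher number from compound 1 to compound 3 (1.00 log units; beyond the scatter), which shows that a larger group at this chain position went with a much lower number, while a 2.2-fold lower number from compound 2 to compound 3 (0.34 log units; beyond the scatter) shows that a shorter chain carrying the same ether ended higher. Within the data shown here, a modest lowering is therefore expected, a 2.9-fold lower number from compound 3 to compound 4 (0.46 log units; beyond the scatter), though no measured compound carries a plain longer alkyl chain. Compound 4 is estimated at 2000 nM, within 600 nM to 7000 nM.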

Compound 4, concentration for 50% growth inhibition: 6500 nM
The estimate for compound 4 lay 3.3-fold (0.51 log units) below the measured number; the measured number falls inside the stated range.
By their numbers in this assay, from the lowest: compound 1; then compounds 3, 4 and 2 (each within the scatter of the next, the first and the last beyond it).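

In this assay the plain octyl chain gave a 1.1-fold higher number from compound 3 to compound 4 (0.05 log units; within the scatter) and then a 1.9-fold lower number from compound 2 to compound 4 (0.29 log units; within the scatter) so added pentyl alone did not separate compound 4 from either neighbour. Only the longer ether chain stood apart, with an 11-fold higher number from compound 1 to compound 4 (1.05 log units; beyond the scatter) showing that, among these compounds, the lower number went with the 4-methylphenoxy end on the longer chain and not with chain length alone. Nothing at hand accounts for this. The compounds shown leave open whether a phenyl end without the ether oxygen would match compound 1. They also leave open how an amine or a carboxylic acid at the chain end would read.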